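The compounds below may be only part of what the source reports. "The series", "measured", "known", "first", "only" and "open" are said of these compounds alone.

Compound 1 `O/N=C(/Nc1ccc(F)c(F)c1)c1ccc2occc2c1` in an assay on isolated protein for inhibition of Indoleamine 2,3-dioxygenase 1 (Homo sapiens), read by spectrophotometry (on this read-out lower numbers stand for stronger inhibition and higher numbers for weaker inhibition), gives 22700 nM. Compound 2 `O/N=C(/Nc1ccc(F)c(Cl)c1)c1ccc2occc2c1` carries the change chloro in place of fluoro on an aromatic carbon and in this assay gives 5200 nM, a step of a 4.4-fold lower number from compound 1 to compound 2 (0.64 log units; beyond the scatter). Compound 3 `O/N=C(/Nc1cccc(F)c1)c1ccc2oc(COCC3CC3)cc2c1` rests on a different core from compound 1; the difference between the two cores is not broken down here. In this assay compound 3 gives 2200 nM, the lowest of the three numbers. Compound 4 `O/N=C(/Nc1cccc(Cl)c1)c1ccc2oc(COCC3CC3)cc2c1` is not yet measured; it differs from compound 3 by chloro in place of fluoro on an aromatic carbon. This is the same kind of change as that from compound 1 to compound 2, not the same: there the place was also ortho to a fluoro group, here it is meta to a large group only. The step from compound 3 to compound 4 in this assay is expected to be a 2.8-fold lower number from compound 3 to compound 4 (0.44 log units; beyond the scatter), a little smaller than the earlier one, since the one measured case, a 4.4-fold lower number from compound 1 to compound 2 (0.64 log units; beyond the scatter), stands on a place that also carried an ortho fluoro group. Compound 4 is estimated at 800 nM, likely between 300 nM and 2200 nM.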

Compound 4, half-maximal inhibitory concentration: 1500 nM
For compound 4 the middle estimate is 1.9-fold (0.27 log units) below the measured one; the measured number falls inside the stated range.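

In this assay the exchange of fluoro for chloro on the aromatic carbon gives a 1.5-fold lower number from compound 3 to compound 4 (0.17 log units; within the scatter), so on the core of compound 3 this change leaves the two compounds indistinguishable on this read-out. The size of the step therefore does not carry over from one core to the other in these two pairs: the same change on two cores in this assay, a 4.4-fold lower number (0.64 log units; beyond the scatter) from compound 1 to compound 2 and a 1.5-fold lower number (0.17 log units; within the scatter) from compound 3 to compound 4, 3.0-fold (0.47 log units) apart, beyond the scatter of two such steps

This does not show which difference sets the two steps apart, since the pairs differ both in the core and in the surroundings of the exchanged atom, and two pairs give no rule for any further core in the series.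

Still open, on these data alone, is how the step behaves when only the core changes and the surroundings of the exchanged atom stay the same, as with a 3-fluorophenyl and 3-chlorophenyl pair on the core of compound 1. Also open, as far as these compounds go, is whether bromo, methyl, trifluoromethyl or nitrile at the same place, or an amine or a carboxylic acid on the side chain of compound 3, would shift the read-out further.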